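Removing the Fluorine from a Weak Receptor Binder

The source may report more compounds than this note shows. Statements on the series, on what has been measured and on what is new or still open speak of the compounds shown alone.

Measured compounds:
- compound 1, `CS(=O)(=O)c1ccc(C(=O)N2CCC(C(=O)N3CCc4ccccc43)CC2)cc1[N+](=O)[O-]`, in an assay on isolated protein for inhibition of thyroid hormone receptor beta (Homo sapiens), read by fluorescence polarization; on this read-out higher numbers stand for weaker inhibition and lower numbers for stronger inhibition: > 60000 nM
- compound 2, `CN(Cc1ccccc1F)C(=O)CNC(=O)c1ccc(S(C)(=O)=O)c([N+](=O)[O-])c1`: 24000 nM

Compound 1 gives only a limit of the assay, (the limit of > 60000 nM in this assay, at which 1 of the 2 values shown sits). Among the measured compounds shown here, compound 2 is therefore the one compound with an actual number in this assay, 24000 nM, and it is a weak inhibitor. Compound 3, `CN(Cc1ccccc1)C(=O)CNC(=O)c1ccc(S(C)(=O)=O)c([N+](=O)[O-])c1`, differs from compound 2 in one place: hydrogen in place of fluoro on an aromatic carbon, ortho to a large group, which turns the 2-fluorobenzyl of compound 2 into a plain benzyl. For the measured compounds named here, no measured pair shows the effect of such a change here. A single fluorine on the benzyl group is expected to make little difference, so the step of a 1.3-fold higher number from compound 2 to compound 3 (0.10 log units; within the scatter) is estimated to lie within the usual scatter. Compound 3 is thus expected to give about 30000 nM in this assay, within 10000 nM to 80000 nM.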

Compound 3, half-maximal inhibitory concentration: 39000 nM
Beside the measured number, compound 3's estimate is 1.3-fold (0.11 log units) below it, and the stated range covers the measured number.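

Among the compounds shown here, exchanging hydrogen for the fluoro in this assay gives a 1.6-fold higher number from compound 2 to compound 3 (0.21 log units; within the scatter), the first measured step between two compounds that differ in one place. At this position on the aromatic carbon, ortho to a large group, the fluorine is therefore not required for a measurable number, since compound 2 and compound 3 both give actual values rather than a limit. Nothing measured here gives a cause for this step.

The compounds shown leave open whether a chlorine, a methoxy group or an amine at this position would move the number beyond the scatter. They also leave open what a nitrile or a carboxylic acid in place of the nitro group on the shared core would do.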